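Reversing the amide and trading benzyl for an oxane ring

A few compounds are considered here, and "the series" means these few. Any claim that something is new, unique, unknown or untested is made for them only; others in the source may bear on it.

Measured so far:
compound 1, `Cc1cc(C(=O)Nc2ccccc2)nn1Cc1cc(Cl)ccc1OCc1ccccc1`, 39.8 nM
compound 2, `Cc1cc(C(=O)NCc2ccccc2)nn1Cc1cc(Cl)ccc1OCc1ccccc1`, 39.8 nM

Both were tested in an assay on CHO-K1 cells for displacement of a labelled ligand from prostaglandin E2 receptor EP1 subtype (Homo sapiens); on this read-out lower numbers stand for stronger inhibition and higher numbers for weaker inhibition. Compound 2 stands level with compound 1, the step of no change at the digits printed from compound 1 to compound 2 (within the scatter). Compound 3, `Cc1cc(NC(=O)C2CCOCC2)nn1Cc1cc(Cl)ccc1OCc1ccccc1`, is not yet measured; it differs from compound 2 by ((oxan-4-yl)carbonyl)amino in place of benzylcarbamoyl on an aromatic carbon. For the measured compounds named here, no measured step touches this change; the one known step only shows that changing the group on the amide nitrogen left binding unchanged, while here the amide itself is turned around and a non-aromatic ring replaces the aromatic one. A modest loss is expected, a 2.5-fold higher number from compound 2 to compound 3 (0.40 log units; beyond the scatter), and compound 3 is estimated at 100 nM, between 25 nM and 400 nM.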

Compound 3, half-maximal inhibitory concentration: 63.1 nM
Compound 3: middle estimate off by 1.6-fold (0.20 log units), on the high side; measured number inside the range.
By their numbers in this assay, from the lowest: compounds 1, 2 and 3 (each within the scatter of the next).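

In this assay, ((oxan-4-yl)carbonyl)amino in place of benzylcarbamoyl gives (a 1.6-fold higher number from compound 2 to compound 3 (0.20 log units; within the scatter)), and in place of phenylcarbamoyl it gives (a 1.6-fold higher number from compound 1 to compound 3 (0.20 log units; within the scatter)). This aromatic carbon therefore tolerates a reversed amide carrying a non-aromatic oxygen-containing ring, not only a change of group on the amide nitrogen. Nothing measured here offers a reason for this tolerance. These compounds do not separate reversing the amide from exchanging the ring. As far as these compounds go, it also remains open whether a piperidine ring carrying an amine nitrogen, or a carboxylic acid, would fit here.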